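Bis-chalcone series: bromo on the pendant phenyl

The source may report more compounds than this note shows. Statements on the series, on what has been measured and on what is new or still open speak of the compounds shown alone.

Compound 1 `Cc1cc(O)c(C(=O)/C=C/c2ccc(Cl)cc2)c(-c2ccccc2)c1C(=O)/C=C/c1ccc(Cl)cc1` is the anchor of the set. In a functional assay on MDA-MB-231 cells (Homo sapiens) for cytotoxicity, read by MTT assay, with a stated time of 24 h (a higher number here means a weaker inhibitor, a lower number a stronger inhibitor), compound 1 gives 7900 nM, the lowest of the two numbers reported. Compound 3 `Cc1cc(O)c(C(=O)/C=C/c2ccc(F)cc2)c(-c2ccc(Br)cc2)c1C(=O)/C=C/c1ccc(F)cc1`, which carries a 4-bromophenyl and fluoro-substituted cinnamoyl arms, gives 22300 nM in this assay, a gap beyond the scatter. Compound 2 `Cc1cc(O)c(C(=O)/C=C/c2ccccc2Cl)c(-c2ccccc2)c1C(=O)/C=C/c1ccccc1Cl` was reported as "not active" (no number reported) in this assay, without a number.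

Compound 4 `Cc1cc(O)c(C(=O)/C=C/c2ccc(Cl)cc2)c(-c2ccc(Br)cc2)c1C(=O)/C=C/c1ccc(Cl)cc1` differs from compound 1 in a single place: bromo in place of hydrogen on an aromatic carbon. For the measured compounds named here, no directly comparable pair is measured, so the step is only guessed. For compound 4 the expected step is a 1.4-fold higher number from compound 1 to compound 4 (0.14 log units; within the scatter), with the most likely result close to the scatter or slightly weakening. Compound 4 is thus estimated at 11000 nM in this assay, within 4500 nM to 30000 nM.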

Compound 4, half-maximal inhibitory concentration: 15000 nM
The estimate for compound 4 lay 1.4-fold (0.13 log units) below the measured number; the range from low to high includes it.
By their numbers in this assay, from the lowest: compounds 1, 4 and 3 (each within the scatter of the next, the first and the last beyond it).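

In this assay, the change from phenyl to 4-bromophenyl, with both chloro-substituted cinnamoyl arms unchanged, gives a 1.9-fold higher number from compound 1 to compound 4 (0.28 log units; within the scatter). This single-place comparison shows that the pendant ring accepts bromo, para to a large group, without a step beyond the scatter. No measured evidence bears on this result.

Still open, on these data alone, is whether an amine, a carboxylic acid or a methoxy group at this position would also stay within the scatter. Also open, as far as these compounds go, is whether bromo gives a similar step when the cinnamoyl arms carry other substituents.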